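Series notes: chain substituent at the alkenyl amide

The source may hold more compounds than are shown below. What is called first, only, known or untested is meant among the compounds shown, and "the series" means these compounds.

Compound 1, `CN(C(=O)/C=C/c1ccc(C(C)(C)C)cc1)c1ccc2c(c1)OCCO2`: in a functional assay on CHO cells for inhibition of transient receptor potential cation channel subfamily V member 1 (Homo sapiens) (a lower number here means a stronger inhibitor, a higher number a weaker inhibitor), compound 1 gives > 4000 nM, a limit of the assay.
Compound 2, `CC(C)(C)c1ccc(C2CC2C(=O)Nc2ccc3c(c2)OCCO3)cc1`: compound 2 gives > 4000 nM, also a limit.
Compound 3, `CC(C)C/C(=C\C(=O)Nc1ccc2c(c1)OCCO2)c1ccc(C(C)(C)C)cc1`: compound 3 gives 94 nM.

Among the measured compounds shown here, compound 3 holds the only numerical value in this assay; the two other entries are limits, as noted in the limit of > 4000 nM in this assay, at which 2 of the 3 values shown sit. For the measured compounds named here, no pair of measured compounds differs in a single place, so no measured step is available.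

Compound 4, `CN(C)CCC/C(=C\C(=O)Nc1ccc2c(c1)OCCO2)c1ccc(C(C)(C)C)cc1`, differs from compound 3 by 2-(dimethylamino)ethyl in place of isopropyl on a saturated chain carbon bound to a double-bonded chain carbon. Without a measured step to lean on, the change is expected to cost some potency in this assay; the step from compound 3 to compound 4 is estimated at a 3.2-fold higher number from compound 3 to compound 4 (0.50 log units; beyond the scatter). For compound 4 the expected value is 300 nM, with a likely range from 60 nM to 2000 nM.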

Compound 4, half-maximal inhibitory concentration: > 4000 nM
Compound 4 gave a limit, no number; the forecaster's own chance of this, stated with the estimate: 20%; middle value at least 13-fold (1.12 log units) from the limit.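

Among the compounds shown here, this gives the first measured step at this position: in this assay, 2-(dimethylamino)ethyl in place of isopropyl gives an at least 42-fold higher number from compound 3 to compound 4 (1.62 log units; beyond the scatter). The activity of compound 3 therefore does not survive every chain at this carbon. Compound 4 gives a limit, not a number, and joins the other inactive entries: the limit of > 4000 nM in this assay, at which 3 of the 4 values shown sit.

As far as these compounds go, the true size of the step stays open, as does whether the loss follows the nitrogen or the longer chain. A plain pentyl chain or a methoxyethyl chain at this position would help separate the two.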